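From carboxy to propoxycarbonyl: expectation for compound 4

The source may hold more compounds than are shown below. What is called first, only, known or untested is meant among the compounds shown, and "the series" means these compounds.

Measured in a functional assay on cells (Platelet, Homo sapiens) for inhibition; a higher number here means a weaker inhibitor, a lower number a stronger inhibitor:
compound 1 `CCOC(=O)c1ccc(-c2nn(Cc3cccc(F)c3)c3ccccc23)cc1`: 270 nM
compound 2 `CCOC(=O)c1ccc(-c2nn(Cc3ccccc3OC)c3ccccc23)cc1`: 470 nM
compound 3 `O=C(O)c1ccc(-c2nn(Cc3ccccc3)c3ccccc23)cc1`: > 10000 nM (a limit, not a number)

Compound 3 stands at the limit of > 10000 nM in this assay, at which 1 of the 3 values shown sits. Compound 4 `CCCOC(=O)c1ccc(-c2nn(Cc3ccccc3)c3ccccc23)cc1` differs from it by carboxy to propoxycarbonyl, that is, propyl in place of hydrogen on an oxygen next to a carbonyl group.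

For the measured compounds named here, no measured step covers this change. The only one, a 1.7-fold higher number from compound 1 to compound 2 (0.24 log units; within the scatter), lies elsewhere on the molecule and stays within the scatter, so a swap at that place need not move the value much. The closest guide is therefore the ester compounds: compound 1 gives 270 nM and compound 2 gives 470 nM, both with measurable numbers. Going by the values given here, compound 4 also carries an ester, though with a longer chain, and no measured compound shows what that chain does.

A large move to a lower number in this assay is expected, estimated as an at least 25-fold lower number from compound 3 to compound 4 (1.39 log units; beyond the scatter). For compound 4 the expected value is 400 nM, with an estimated range of 120 nM to 1500 nM.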

Compound 4, half-maximal inhibitory concentration: > 10000 nM
Compound 4: a limit, no number; the forecaster's own chance of this, stated with the estimate: 5%; at least 25-fold (1.39 log units) between middle value and limit.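

No step can be read from compound 3 to compound 4, as both values are limits and not numbers: the limit of > 10000 nM in this assay, at which 2 of the 4 values shown sit. The compounds shown leave open whether propoxycarbonyl in place of carboxy on the shared core changes the value at all.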